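The source may report more compounds than this note shows. Statements on the series, on what has been measured and on what is new or still open speak of the compounds shown alone.

Measured so far:
compound 1, `Oc1ccccc1/C=N/c1nnc(SCc2nnc(-c3ccc(F)cc3)o2)s1`, 20100 nM
compound 2, `Oc1ccccc1/C=N/c1nnc(SCc2nnc(-c3ccc(Cl)cc3)o2)s1`, 30100 nM
compound 3, `Oc1ccccc1/C=N/c1nnc(SCc2nnc(-c3ccc(Br)cc3)o2)s1`, 20000 nM

These three compounds were all tested in a functional assay on A549 cells (Homo sapiens) for inhibition, read by CCK-8 assay; on this read-out lower numbers stand for stronger inhibition and higher numbers for weaker inhibition. They share one core and differ only in the halogen on the phenyl ring. Compound 3 sits alongside the other two: the change a 1.0-fold lower number from compound 1 to compound 3 (0.00 log units; within the scatter) and the change a 1.5-fold lower number from compound 2 to compound 3 (0.18 log units; within the scatter) are both within the scatter, as is a 1.5-fold higher number from compound 1 to compound 2 (0.18 log units; within the scatter). So swapping one halogen for another at this spot has not moved the number in a way that can be trusted.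

Compound 4, `Cc1ccccc1-c1nnc(CSc2nnc(/N=C/c3ccccc3O)s2)o1`, has not yet been measured. It differs from compound 3 in one place: 2-methylphenyl in place of 4-bromophenyl on an aromatic carbon. For the measured compounds named here, none of the measured steps covers this kind of change; they only exchange one halogen for another on the same ring, and each was within the scatter. With nothing pointing either way, the expectation is that compound 4 behaves much like compound 3 in this assay, with a step of a 1.1-fold higher number from compound 3 to compound 4 (0.04 log units; within the scatter) that is not expected to exceed the scatter. The estimate for compound 4 is therefore 22000 nM, within a range from 8000 nM to 60000 nM.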

Compound 4, half-maximal inhibitory concentration: 7850 nM
Compound 4: the middle estimate sits 2.8-fold (0.45 log units) above what was measured; measured number below the stated range.
By their numbers in this assay, from the lowest: compound 4; then compounds 3, 1 and 2 (each within the scatter of the next).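

Across the halogen swaps in this assay, this part of the molecule seemed to make little difference, but replacing the whole halogen-bearing phenyl group with 2-methylphenyl gives a modest shift beyond the scatter against all three earlier compounds: a 2.5-fold lower number from compound 3 to compound 4 (0.41 log units; beyond the scatter), a 3.8-fold lower number from compound 2 to compound 4 (0.58 log units; beyond the scatter) and a 2.6-fold lower number from compound 1 to compound 4 (0.41 log units; beyond the scatter). The number at this position can therefore move, and compound 4 shows the strongest inhibition of the four, even though the leaving and entering groups have the same count of heavy atoms and neither has hydrogen-bond donors or acceptors. Nothing available explains the gain, so the shift remains an observation without a demonstrated cause.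

This change alters both the kind of substituent, methyl instead of halogen, and its location on the phenyl ring, so the compounds shown cannot tell which of the two matters. As far as these compounds go, it also remains open whether an ethyl group, a methoxy group or an amine on that phenyl ring would lower the number further, leave it unchanged or raise it.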